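This account rests on a few compounds, and the source may have more. Where it says the series, first, only, none or still open, it means among the compounds named here.

Of the compounds shown here, two from one series have been measured in a functional assay on HEK293 cells for agonist activity at D(4) dopamine receptor (Homo sapiens), read by FLIPR; a lower number here means a smaller maximal response, a higher number a larger maximal response. Compound 1 `O=C(NCN1CCC(c2cccc[n+]2[O-])CC1)c1ccccc1` gives 63% in this assay, and of the two numbers recorded it stands highest. Compound 2 `Cc1cccc(NC(=O)CN2CCC(c3ccccc3)CC2)c1` gives 37% in this assay, a number that lies below that of compound 1 by more than the usual scatter. Within the data shown here, no single-change step connects these two measured compounds, so their two values can only be set side by side and say nothing about any one alteration.

The step now followed leads from compound 1 to compound 3 `Cc1cc(C(=O)NCN2CCC(c3cccc[n+]3[O-])CC2)ccc1Cl`. The change is 4-chloro-3-methylphenyl in place of phenyl on a carbonyl carbon. The core of compound 1 is kept; only the group on the carbonyl carbon is exchanged. Among the measured compounds shown here, with no measured step of this kind to draw on, the change expected in this assay is a number 3 percentage points lower from compound 1 to compound 3 (within the scatter), a shift estimated to stay within or close to the scatter. Compound 3 is therefore expected to give about 60% in this assay, with a range from 40% to 80%.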

Compound 3, largest response reached (reported as efficacy), in percent of the reference or control that the assay uses: 62%
For compound 3 the middle estimate is 2 percentage points below the measured one, and the stated range covers the measured number.
By their numbers in this assay, from the lowest: compound 2; then compounds 3 and 1 (each within the scatter of the next).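

Among these compounds, exchanging phenyl for 4-chloro-3-methylphenyl on the carbonyl carbon gives the first single-change step, and in this assay it reads as a number 1 percentage points lower from compound 1 to compound 3 (within the scatter) for this change. Among the compounds shown here, the group on this carbonyl carbon can therefore carry a chlorine and a methyl on its ring with no shift in maximal response that stands out from the scatter, something no earlier pair could show. Nothing at hand offers a reason for this result.

This is a single step, so it says nothing about how the chlorine and the methyl each act alone, and two opposing effects cannot be told apart from no effect at all. It also leaves open whether the same level of response would hold with a quite different group on the carbonyl carbon, such as a carboxylic acid, an amine or a longer carbon chain in place of the phenyl.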